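Pyridin-4-yl in place of 4-bromophenyl: an estimate

The source may hold more compounds than are shown below. What is called first, only, known or untested is meant among the compounds shown, and "the series" means these compounds.

Compound 1 `O=C(NO)c1ccc(NCc2nc(-c3ccc(Br)cc3)nn2-c2ccccc2)cc1`: 54.7%
Compound 2 `Nc1ccccc1NC(=O)c1ccc(NCc2nc(-c3ccccc3)nn2-c2ccccc2)cc1`: 5%

Of the compounds shown here, two have been measured in an assay on Sf9 cells for inhibition of protein deacetylase HDAC6 (Homo sapiens), read by fluorescence, with a stated time of 40 min, tested at 100 nM; a lower number here means less inhibition, a higher number more inhibition at the concentration tested (going by the name of the read-out). Compound 1 gives 54.7%, while compound 2 gives 5%. Within the data shown here, compound 1 thus stands highest of the two numbers, and its only neighbour, compound 2, reads lower by a gap that lies beyond the usual scatter. Among the measured compounds shown here, no pair of measured compounds differs in just one place, so these two values show only that two structures differing in several places read far apart.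

Compound 3 `O=C(NO)c1ccc(NCc2nc(-c3ccncc3)nn2-c2ccccc2)cc1` has not yet been measured in this assay . It differs from compound 1 in one place: pyridin-4-yl in place of 4-bromophenyl on an aromatic carbon. Everything else in compound 1 is kept. For the measured compounds named here, with no single-place step measured, the expected size of the step in this assay can rest only on compound 1 itself, which gives 54.7%; a modest downward move is expected, possibly not beyond the scatter. Compound 3 is therefore estimated at 45%, between 20% and 70%, an expected step of a number 9.7 percentage points lower from compound 1 to compound 3 (within the scatter).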

Compound 3, a percentage reported as inhibition, at one concentration (the size of the read-out at that concentration, not a potency): 30.8%
Estimate against measurement, compound 3: 14.2 percentage points above, within the range that was stated.
By their numbers in this assay, from the lowest: compound 2; then compound 3; then compound 1.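

Pyridin-4-yl in place of 4-bromophenyl gives a number 23.9 percentage points lower from compound 1 to compound 3 (beyond the scatter) in this assay, the first comparison in this set that changes only one place, and it shows that the number responds to what sits on this aromatic carbon of the five-membered aromatic ring with 3 nitrogen. The response is partial, as compound 3 still reads 30.8%, so at the concentration tested this change lowers the inhibition without removing it. No measurement at hand accounts for the step.

The compounds shown leave open whether the step goes with the departure of the bromine or with the arrival of the ring nitrogen of pyridin-4-yl, as the two change together here. They also leave open how an unsubstituted phenyl, a 4-chlorophenyl or a 4-aminophenyl would read at this same place on the core of compound 1, and so whether the number follows the para bromine alone or the ring as a whole.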